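Compound 3 without one hydroxy group

The source may hold more compounds than are shown below. What is called first, only, known or untested is meant among the compounds shown, and "the series" means these compounds.

Measured so far in a functional assay on HT-29 cells (Homo sapiens) for inhibition, read by sulforhodamine B assay, with a stated time of 48 h; a higher number here means a weaker inhibitor of growth, a lower number a stronger inhibitor of growth:
Compound 1 `CCOC(=O)C1=C(C)NC(=S)NC1c1ccc(O)c(O)c1` gives 33.7 ug/mL
Compound 2 `CCOC(=O)C1=C(C)NC(=S)NC1c1ccc(F)cc1` gives 26.5 ug/mL
Compound 3 `CCOC(=O)C1=C(C)NC(=O)NC1c1ccc(O)c(O)c1` gives 37.8 ug/mL

In this assay compound 3 gives 37.8 ug/mL and lies within the scatter of both other compounds, so the three values do not separate from one another. Compound 4 `CCOC(=O)C1=C(C)NC(=O)NC1c1ccc(O)cc1` has yet to be measured. Set against compound 3, it has hydrogen in place of hydroxy on an aromatic carbon at a place ortho to a hydroxy group and meta to a large group.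

Among the measured compounds shown here, no two measured compounds differ in one place only, so the data hold no direct measure of this change. They do show a narrow spread, with compound 1 at 33.7 ug/mL and compound 2 at 26.5 ug/mL both within the scatter of compound 3. On that basis, no step beyond the scatter is expected in this assay, and neither direction is favoured. The estimated step is a 1.1-fold lower number from compound 3 to compound 4 (0.03 log units; within the scatter) and nothing larger is expected. For compound 4 the expected value is 35 ug/mL with an estimated range of 18 ug/mL to 70 ug/mL when it is measured.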

Compound 4, concentration for 50% growth inhibition: 28.7 ug/mL
The estimate for compound 4 lay 1.2-fold (0.09 log units) above the measured number, within the range that was stated.
By their numbers in this assay, from the lowest: compounds 2, 4, 1 and 3 (each within the scatter of the next).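

In this assay, among the compounds shown here, hydrogen in place of hydroxy on an aromatic carbon, ortho to a hydroxy group and meta to a large group, gives a 1.3-fold lower number from compound 3 to compound 4 (0.12 log units; within the scatter), the first comparison in this set between two compounds that differ in one place only. Compound 3 and compound 4 do not separate, so at this place, with the other hydroxy group and the carbonyl kept, the presence of this hydroxy group makes no difference that can be told from the scatter of this assay. Nothing measured here bears on why the two compounds read alike.

The compounds shown leave open whether a methoxy group, an amine or a fluorine atom at this same place would give a step beyond the scatter, and whether removing the remaining hydroxy group as well would do so. They also leave open whether the same swap of hydroxy for hydrogen would read the same on the core of compound 1, which carries sulfur where compound 3 carries the carbonyl oxygen.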